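The source may hold more compounds than are shown below. What is called first, only, known or untested is meant among the compounds shown, and "the series" means these compounds.

Within the data shown here, in an in vitro ADME assay on microsomes from liver (Homo sapiens) for pharmacokinetics (on this read-out lower numbers stand for slow clearance and higher numbers for fast clearance), compound 3 `Cc1cc(S(=O)(=O)N2C=CNC(=O)[C@H]2CC(=O)N[C@H]2CCNCC2(C)C)c(C)cc1Cl` gives 21 mL.min-1.g-1, the only true number among the measured compounds. Compound 1 `CCCN1CC[C@H](NC(=O)C[C@@H]2C(=O)NC=CN2S(=O)(=O)c2ccc(C)cc2)C(C)(C)C1` is reported as < 50 mL.min-1.g-1, which is a limit of the assay and not a number. Compound 2 `CC1(C)CNCC[C@@H]1NC(=O)C[C@@H]1C(=O)NC=CN1S(=O)(=O)c1ccc(Cl)c(Cl)c1` is also reported only as a limit, < 50 mL.min-1.g-1. The data thus rest largely on (the limit of < 50 mL.min-1.g-1 in this assay, at which 2 of the 3 values shown sit).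

Compound 4 `Cc1cc(S(=O)(=O)N2C=CNC(=O)[C@H]2CC(=O)N2CCC[C@H](N3CCCC3)C2)c(C)cc1Cl` departs from compound 3 on a carbonyl carbon: a group of 11 heavy atoms (9 carbon, 2 nitrogen; one five-membered non-aromatic ring with 1 hetero atom, one six-membered non-aromatic ring with 1 hetero atom) in place of a group of 9 heavy atoms (7 carbon, 2 nitrogen; one six-membered non-aromatic ring with 1 hetero atom), on a carbonyl carbon. Among the measured compounds shown here, the one measured step, a step that the limit leaves unreadable from compound 2 to compound 3, concerns the group on a sulfonyl sulfur rather than this place, and it offers no size to carry over. For the measured compounds named here, no measured step reaches the exchanged group, so the expectation starts from compound 3 at 21 mL.min-1.g-1. The expected change is a 1.4-fold higher number from compound 3 to compound 4 (0.15 log units; within the scatter), which is nothing beyond the usual scatter in this assay, with only a slight lean towards faster clearance. For compound 4 the estimated value is 30 mL.min-1.g-1, with an expected range from 12 mL.min-1.g-1 to 75 mL.min-1.g-1.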

Compound 4, intrinsic clearance in microsomes: 235 mL.min-1.g-1
The estimate for compound 4 lay 7.8-fold (0.89 log units) below the measured number; measured number above the stated range.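

In this assay, among these compounds, the exchange on a carbonyl carbon gives an 11-fold higher number from compound 3 to compound 4 (1.05 log units; beyond the scatter) and so shows that this place, which no earlier readable step had reached, can move clearance strongly. The group that enters has a five-membered non-aromatic ring in addition to a six-membered one and 0 hydrogen-bond donors, where the group that leaves has 2, so this single step cannot separate these differences. Among the compounds shown here, it is the only step that can be sized, and the step on the sulfonyl sulfur cannot be read because the comparison rests on a limit: the limit of < 50 mL.min-1.g-1 in this assay, at which 2 of the 4 values shown sit.

The compounds shown leave open whether the five-membered ring itself accounts for the step, or whether a dimethylamino group or a morpholine in its place would read the same way in this assay. They also leave open whether the step would hold with 3,4-dichlorophenyl on the sulfonyl sulfur.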